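The source may hold more compounds than are shown below. What is called first, only, known or untested is meant among the compounds shown, and "the series" means these compounds.

Measured compounds in an ADME assay on HEK293 cells (Homo sapiens) for cytotoxicity, read by CCK-8 assay and cell counting, with a stated time of 2 days; a higher number here means a weaker inhibitor, a lower number a stronger inhibitor:
- compound 1 `Oc1ccc(-c2cc(-c3cccc(Cl)c3)nc(-c3cccs3)c2)cc1` gives 2720 nM
- compound 2 `Oc1ccc(-c2cc(-c3ccncc3)nc(-c3cccc(Cl)c3)c2)cc1` gives "not determined" (no result reported)
- compound 3 `Oc1ccc(-c2cc(-c3ccsc3)nc(-c3cccc(Cl)c3)c2)cc1` gives 2670 nM

Compound 3 holds the lowest of the two numbers, but its nearest neighbour is compound 1, and the step of a 1.0-fold lower number from compound 1 to compound 3 (0.01 log units; within the scatter) is within the scatter, so no order between the two can be stated. Compound 2 carries no number in this assay and gives no guidance.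

Compound 4 `Oc1ccc(-c2cc(-c3cccc(Cl)c3)nc(-c3ccco3)c2)cc1` is the next entry, unmeasured. Its change from compound 3 is furan-2-yl in place of thiophen-3-yl on an aromatic carbon. Among the measured compounds shown here, the only measured step that bears on it is the swap of one five-membered aromatic ring with one hetero atom for another at the same carbon, a 1.0-fold lower number from compound 1 to compound 3 (0.01 log units; within the scatter), which produced no movement beyond the scatter. A further exchange of this kind is therefore expected to leave the number where it is, with no step beyond the scatter in either direction, the estimated step being a 1.0-fold higher number from compound 3 to compound 4 (0.00 log units; within the scatter). For compound 4 the estimate in this assay is 2700 nM, with a range from 1400 nM to 5400 nM.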

Compound 4, half-maximal inhibitory concentration: 2880 nM
For compound 4 the middle estimate is 1.1-fold (0.03 log units) below the measured one, within the range that was stated.
By their numbers in this assay, from the lowest: compounds 3, 1 and 4 (each within the scatter of the next).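

In this assay, the aromatic carbon next to the ring nitrogen now accepts a change of hetero atom as well as a change of attachment point: furan-2-yl in place of thiophen-3-yl gives a 1.1-fold higher number from compound 3 to compound 4 (0.03 log units; within the scatter), and furan-2-yl in place of thiophen-2-yl gives a 1.1-fold higher number from compound 1 to compound 4 (0.02 log units; within the scatter). The earlier compounds shown here covered only two thiophene attachments, whereas oxygen for sulfur in the five-membered aromatic ring also stays within the scatter, so the three rings cannot be ordered here. Nothing measured here speaks to why the number holds.

As far as these compounds go, every measured group at this position is a five-membered aromatic ring with one hetero atom, so the effect of an amine, a carboxylic acid or a longer alkyl chain there remains open. The 3-chlorophenyl and 4-hydroxyphenyl groups stay fixed across the measured compounds, leaving replacement of either one open as well.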